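A few compounds are considered here, and "the series" means these few. Any claim that something is new, unique, unknown or untested is made for them only; others in the source may bear on it.

Three compounds of the series carry numbers in a functional assay on A549 cells (Homo sapiens) for cytotoxicity, read by colorimetric assay and MTT assay, with a stated time of 3 days, tested at 1 uM; a higher number here means a weaker effect of the compound at the concentration tested, a lower number a stronger effect. Compound 1 `COc1ccc(-c2nc(-c3ccccc3)c(-c3ccc4c(c3)NC(=O)CO4)[nH]2)cc1` gives 101% and compound 3 `O=C1COc2ccc(-c3[nH]c(-c4ccccc4)nc3-c3ccccc3)cc2N1` gives 95.6%; the step of a number 5.4 percentage points lower from compound 1 to compound 3 (within the scatter) lies within the scatter. Compound 2 `O=C1COc2ccc(-c3nn(-c4ccc(F)cc4)cc3-c3ccccc3)cc2N1` gives 78.2% in this assay, the lowest of the three numbers, beyond the scatter from both compound 3 and compound 1. Compound 4 `Cc1ccccc1-n1cc(-c2ccccc2)c(-c2ccc3c(c2)NC(=O)CO3)n1` has not been measured. It differs from compound 2 as follows: 2-methylphenyl in place of 4-fluorophenyl on an aromatic nitrogen. For the measured compounds named here, no measured step alters the group on the aromatic nitrogen; the only measured step, a number 5.4 percentage points lower from compound 1 to compound 3 (within the scatter), concerns a substituent on an aromatic carbon and does not bear on this change. No step beyond the scatter is therefore expected in this assay. The estimate for compound 4 is 80%, with a range from 60% to 100%. The expected step is a number 1.8 percentage points higher from compound 2 to compound 4 (within the scatter).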

Compound 4, a percentage reported as activity, at one concentration (the size of the read-out at that concentration, not a potency): 94.8%
For compound 4 the middle estimate is 14.8 percentage points below the measured one; the measured number falls inside the stated range.
By their numbers in this assay, from the lowest: compound 2; then compounds 4, 3 and 1 (each within the scatter of the next).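

Within the series, the group on the aromatic nitrogen is not a silent position in this assay: 2-methylphenyl in place of 4-fluorophenyl gives a number 16.6 percentage points higher from compound 2 to compound 4 (beyond the scatter) and so a weaker effect at the concentration tested. For the compounds shown here, this is the first step at this position, and it lies beyond the scatter, unlike the earlier step on an aromatic carbon. Nothing available explains this step.

Open, as far as these compounds go, is whether the step follows from losing the fluorine or from gaining the methyl group, since the two change together. An unsubstituted phenyl, 4-methylphenyl or 2-fluorophenyl on this nitrogen would separate the two.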